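Cyclopentyl for Isopropyl on the Shared Core

The source may report more compounds than this note shows. Statements on the series, on what has been measured and on what is new or still open speak of the compounds shown alone.

Among the measured compounds shown here, compound 1 `CC(C)n1cnc2c(Nc3cccc(Cl)c3)nc(NCOCc3ccc(C(=O)Nc4ccccc4N)cc3)nc21` holds the highest of the two numbers so far recorded in a functional assay on HepG2 cells (Homo sapiens) for antiproliferative activity, read by CCK-8 assay, with a stated time of 72 h, tested at 8 uM; a higher number here means a stronger effect of the compound at the concentration tested, a lower number a weaker effect: in that assay compound 1 gives 60.5%. For the measured compounds named here, its only measured neighbour is compound 2 `CC(C)n1cnc2c(Nc3cccc(Cl)c3)nc(NCOCc3ccc(/C=C/C(=O)Nc4ccccc4N)cc3)nc21`, which in this assay gives 49.9%. The step between them is a number 10.6 percentage points lower from compound 1 to compound 2 (beyond the scatter), and it concerns 2-((2-aminophenyl)carbamoyl)ethenyl in place of (2-aminophenyl)carbamoyl on an aromatic carbon.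

Compound 3 `Nc1ccccc1NC(=O)c1ccc(COCNc2nc(Nc3cccc(Cl)c3)c3ncn(C4CCCC4)c3n2)cc1` has not yet been measured in this assay. It differs from compound 1 in a single place, described as follows (cyclopentyl in place of isopropyl on an aromatic nitrogen).

Going by the values given here, no measured step bears on this change. Among the compounds with values here, the one step available, from compound 1 to compound 2, alters the amide side of the molecule and leaves the group on the aromatic nitrogen untouched, so it says nothing about exchanging isopropyl for cyclopentyl there. With no evidence for a shift in either direction, the expected step is none beyond the scatter, which is what a number 1.5 percentage points lower from compound 1 to compound 3 (within the scatter) means as an estimate. Compound 3 is therefore expected to give about 59% in this assay, estimated to fall between 42% and 74%.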

Compound 3, a percentage reported as inhibition, at one concentration (the size of the read-out at that concentration, not a potency): 63.2%
Estimate against measurement, compound 3: 4.2 percentage points below, within the range that was stated.
By their numbers in this assay, from the lowest: compound 2; then compounds 1 and 3 (each within the scatter of the next).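

In this assay, among the compounds shown here, the exchange of isopropyl for cyclopentyl on the aromatic nitrogen gives a number 2.7 percentage points higher from compound 1 to compound 3 (within the scatter) and is the first measured change at this position. Here a group of 5 heavy atoms with a five-membered non-aromatic ring stands where compound 1 carries one of 3 heavy atoms with no ring, and the read-out at the concentration tested stays within the scatter, unlike the earlier step on the amide side of the molecule, a number 10.6 percentage points lower from compound 1 to compound 2 (beyond the scatter) and thus beyond it. No measured evidence is at hand to account for this result.

The compounds shown leave open whether the same holds for other groups on this nitrogen, such as a cyclohexyl ring, a phenyl ring, a longer chain such as n-butyl, or a ring containing oxygen such as tetrahydropyranyl. They also leave open whether cyclopentyl on this nitrogen would give a similar read-out alongside the 2-((2-aminophenyl)carbamoyl)ethenyl group of compound 2.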